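A Nitrophenyl Swap on the Saturated Ring Carbon

The compounds below may be only part of what the source reports. "The series", "measured", "known", "first", "only" and "open" are said of these compounds alone.

Of the compounds shown here, two have been measured so far. Compound 1 `COc1ccc(/C=C/C(=O)c2ccc(NC(=O)c3cc(Cl)ccc3OC)cc2)cc1` and compound 2 `COc1ccc(C2CC(c3ccc(NC(=O)c4cc(Cl)ccc4OC)cc3)=NN2C)cc1` were both tested in a functional assay on the whole organism (plasma, strain albino) for inhibition, with Rattus norvegicus as the target, with stated times of 1 h and 4 h, at a dose of 50 mg/kg by the oral route; on this read-out lower numbers stand for a weaker effect and higher numbers for a stronger effect at the one dose given. In this assay compound 1 gives 79.2%, and compound 2 gives 81.8%. Compound 2 holds the higher of the two numbers, but the gap to compound 1 lies within the usual scatter of repeated measurements, so the two compounds cannot be told apart on this read-out. Among the measured compounds shown here, no measured pair differs in a single place, so no measured step is available to guide expectations.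

Compound 3 `COc1ccc(Cl)cc1C(=O)Nc1ccc(C2=NN(C)C(c3ccccc3[N+](=O)[O-])C2)cc1` has not yet been measured in this assay. It differs from compound 2 in one place: 2-nitrophenyl in place of 4-methoxyphenyl on a saturated ring carbon. For the measured compounds named here, with only two measured compounds, whose values sit within scatter of each other, there is no footing for expecting a large step; a modest lowering, or no change beyond the scatter, is what is expected in this assay, expressed as a number 9.8 percentage points lower from compound 2 to compound 3 (within the scatter). Compound 3 is estimated to give 72% in this assay, with a range from 52% to 90%.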

Compound 3, a percentage reported as inhibition, in the whole organism at one dose (the size of the read-out at that dose, not a potency): 91.3%
Compound 3: middle estimate off by 19.3 percentage points, on the low side; measured number above the stated range.
By their numbers in this assay, from the lowest: compounds 1, 2 and 3 (each within the scatter of the next, the first and the last beyond it).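

Among the compounds shown here, this is the first step that changes only one place: in this assay, 2-nitrophenyl in place of 4-methoxyphenyl on the saturated ring carbon gives a number 9.5 percentage points higher from compound 2 to compound 3 (within the scatter). The position therefore accepts an exchange of one substituted phenyl group for another with no loss of effect at the one dose given, even though the substituent and where it sits on the phenyl ring both differ. Compound 2 and compound 3 cannot be told apart on this read-out, and nothing available explains why the effect holds across this change.

With only these two groups at the position, the compounds shown do not separate the contribution of the nitro group from that of its place on the phenyl ring, nor show whether the phenyl ring is needed at all. On these data alone, it also remains open whether an amine or a carboxylic acid on that phenyl ring, or a simple methyl group directly on the saturated ring carbon, would keep the effect at this level.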